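Working notes: removing one chloro from compound 1

The source may report more compounds than this note shows. Statements on the series, on what has been measured and on what is new or still open speak of the compounds shown alone.

For the measured compounds named here, in a functional assay on K562 cells (Homo sapiens) for inhibition, read by trypan blue exclusion, with a stated time of 72 h (a higher number here means a weaker inhibitor, a lower number a stronger inhibitor), compound 1 `Cn1c(=O)c(S(=O)(=O)c2ccc(Cl)cc2Cl)cc2cnc(Nc3ccc4[nH]ccc4c3)nc21` gives 1000 nM as its half-maximal inhibitory concentration, the lowest of the three numbers so far. Compound 2 `Cn1c(=O)c(S(=O)(=O)c2ccc(F)cc2)cc2cnc(Nc3ccc4cc[nH]c4c3)nc21` reads 10000 nM in this assay and compound 3 `Cn1c(=O)c(S(=O)(=O)c2ccccc2)cc2cnc(Nc3ccc4ncccc4c3)nc21` reads 100000 nM in the same test, both beyond the scatter from compound 1. Going by the values given here, compounds 2 and 3 each differ from compound 1 in more than one place, so no measured pair isolates a single change.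

The next compound is compound 4 `Cn1c(=O)c(S(=O)(=O)c2ccc(Cl)cc2)cc2cnc(Nc3ccc4[nH]ccc4c3)nc21`. Its difference from compound 1 is hydrogen in place of chloro on an aromatic carbon, which turns 2,4-dichlorophenyl into 4-chlorophenyl. The rest of the structure stays the same, including the 4-chloro group.

Among the compounds with values here, with no direct precedent, the expectation rests on a thin basis. Within the data shown here, only one heavy atom changes, and compound 1 at 1000 nM is the sole measured compound that carries the chloro in question. A modest rise is therefore expected rather than a large shift. The expected step of a 1.8-fold higher number from compound 1 to compound 4 (0.26 log units; within the scatter) is small and is not expected to go clearly beyond the scatter. For compound 4 the estimate is 1800 nM with an estimated range from 400 nM to 10000 nM in this series.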

Compound 4, half-maximal inhibitory concentration: 100 nM
For compound 4 the middle estimate is 18-fold (1.26 log units) above the measured one; the measured number lies below the stated range.
By their numbers in this assay, from the lowest: compound 4; then compound 1; then compound 2; then compound 3.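

Hydrogen in place of chloro on an aromatic carbon, on the step from 2,4-dichlorophenyl to 4-chlorophenyl, gives a 10-fold lower number from compound 1 to compound 4 (1.00 log units; beyond the scatter) in this assay, and this is the first pair in the series that isolates a single change. The position, ortho to a large group and meta to a chloro group, therefore has a clear bearing on this read-out, and in this pair the chloro there goes with the weaker inhibitor, so the 4-chloro group alone reads better than the two chloro groups together on the same core. Nothing available bears on why the loss of this one heavy atom moves the number in this direction.

Still open, from the compounds shown here alone, is whether a methoxy group, a methyl group or an amine at this position would read like the hydrogen of compound 4 or like the chloro of compound 1, and whether the same step would hold with the 4-chloro group replaced. For the compounds shown here, the series also offers no single-change pair for the other sulfonyl aryl groups or for the different bicyclic amine groups of compound 2 and compound 3, so those steps cannot be read.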